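The source may hold more compounds than are shown below. What is called first, only, known or untested is meant among the compounds shown, and "the series" means these compounds.

Compound 1 `Cc1c(C(=O)NCc2cccc(C(F)(F)F)c2)cnn1-c1ccc(F)cc1` and compound 2 `Cc1c(C(=O)NCc2cccc(C(F)(F)F)c2)cnn1-c1ccc(Cl)cc1` share a core and differ only in the halogen on the phenyl ring attached to the ring nitrogen. In a functional assay on cells for antagonist activity at C-C chemokine receptor type 1 (Homo sapiens), read by FLIPR and calcium flux (a lower number here means a stronger inhibitor, a higher number a weaker inhibitor), compound 1 gives 790 nM, and compound 2 gives 600 nM. Compound 1 therefore stands highest of the two numbers, but the step of a 1.3-fold lower number from compound 1 to compound 2 (0.12 log units; within the scatter) is small, so the two compounds cannot be ordered against each other.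

Compound 3 `Cc1cccc(-n2ncc(C(=O)NCc3cccc(C(F)(F)F)c3)c2C)c1` is not yet measured. It differs from compound 1 in one place: 3-methylphenyl in place of 4-fluorophenyl on an aromatic nitrogen. Within the data shown here, no measured step covers this change. Among the measured compounds shown here, the only step available, a 1.3-fold lower number from compound 1 to compound 2 (0.12 log units; within the scatter), exchanges one halogen for another at the same position and leaves the number essentially where it was; it says nothing about a methyl group placed on a different ring carbon. The expectation is therefore anchored on compound 1 with wide uncertainty. Compound 3 is expected to give 1000 nM in this assay, with a range of 300 nM to 3500 nM, which as a step means a 1.3-fold higher number from compound 1 to compound 3 (0.10 log units; within the scatter), no more than the scatter.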

Compound 3, half-maximal inhibitory concentration: > 3000 nM
Compound 3: no number, only a limit; the forecaster's own chance of this, stated with the estimate: 5%; at least 3.0-fold (0.47 log units) between middle value and limit.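

Compound 3 has no number in this assay, only a limit: the limit of > 3000 nM in this assay, at which 1 of the 3 values shown sits. Even so, replacing the halogen-bearing phenyl group on the aromatic nitrogen with 3-methylphenyl can be read against both measured compounds, giving an at least 3.7-fold higher number from compound 1 to compound 3 (0.57 log units; beyond the scatter) and an at least 5.0-fold higher number from compound 2 to compound 3 (0.69 log units; beyond the scatter). The exchange of one halogen for the other had stayed within the scatter, so it left it unclear whether this position responds to change at all, whereas these steps show that compound 3 is a weaker inhibitor than either halogen compound and that the group on this nitrogen is not freely interchangeable.

Because 3-methylphenyl differs from the 4-halophenyl groups in both the group carried and the numbered ring position, the compounds shown cannot separate those two changes, a question that a 4-methylphenyl or 3-fluorophenyl group would address. Also open, going by these compounds, are how far the number of compound 3 lies past its limit and how this position would respond to an amine or a carboxylic acid on the phenyl ring.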